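A few compounds are considered here, and "the series" means these few. Any claim that something is new, unique, unknown or untested is made for them only; others in the source may bear on it.

Measured compounds:
Compound 1 `CCCCCNc1ncnc2c1ncn2[C@@H]1O[C@H](CO)[C@@H](O)[C@H]1O` gives 13500 nM in an assay on isolated protein for binding affinity to Equilibrative nucleoside transporter 1 (Homo sapiens); a lower number here means a stronger inhibitor, a higher number a weaker inhibitor.
Compound 2 `N#Cc1ccc(SCc2ncnc3c2ncn3[C@@H]2O[C@H](CO)[C@@H](O)[C@H]2O)cc1` gives 81.3 nM in this assay.
Compound 3 `Cc1ccc([N+](=O)[O-])c(CNc2ncnc3c2ncn3[C@@H]2O[C@H](CO)[C@@H](O)[C@H]2O)c1` gives 1290 nM in this assay.

Compound 3 stands second of the three on these numbers, with compound 1 a good way above it and compound 2 well below it. The step to compound 4 `COc1cccc(CNc2ncnc3c2ncn3[C@@H]2O[C@H](CO)[C@@H](O)[C@H]2O)c1` is 3-methoxyphenyl in place of 5-methyl-2-nitrophenyl on a saturated chain carbon bound to a nitrogen on an aromatic ring. Among the compounds with values here, the only measured step at this position is a 10-fold lower number from compound 1 to compound 3 (1.02 log units; beyond the scatter), which swapped a plain chain for an aromatic ring; here one aromatic ring replaces another, so that step bears only loosely, and compound 2 carries a different linker. A modest step in this assay is expected, in either direction, a 1.4-fold lower number from compound 3 to compound 4 (0.16 log units; within the scatter). Compound 4 is estimated at 900 nM, with a range of 200 nM to 4000 nM.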

Compound 4, half-maximal inhibitory concentration: 115000 nM
Compound 4: the middle estimate sits 130-fold (2.11 log units) below what was measured; the measured number lies above the stated range.
By their numbers in this assay, from the lowest: compound 2; then compound 3; then compound 1; then compound 4.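

In this assay, an aromatic ring at this position does not bring a gain by itself. The outcome differs with what the ring carries: the swap gives an 89-fold higher number from compound 3 to compound 4 (1.95 log units; beyond the scatter). Against the chain, the 3-methoxyphenyl group even loses ground, with an 8.5-fold higher number from compound 1 to compound 4 (0.93 log units; beyond the scatter), whereas the 5-methyl-2-nitrophenyl group gained. Nothing available explains this difference.

Going by these compounds, the swap changes the methyl, nitro and methoxy groups all at once, so which of them matters remains open. A plain phenyl ring, or a ring carrying only the nitro group, could begin to separate them.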